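Swapping Bromo for Nitro on the Benzoyl Ring

A few compounds are considered here, and "the series" means these few. Any claim that something is new, unique, unknown or untested is made for them only; others in the source may bear on it.

The measured compounds and their numbers in a functional assay on DU-145 cells (Homo sapiens) for inhibition, read by trypan blue exclusion, with a stated time of 96 h; a lower number here means a stronger inhibitor of growth, a higher number a weaker inhibitor of growth:
compound 1, `O=C(/C(=C\c1ccc(O)cc1)SCc1ccc(Cl)cc1)c1ccc(Br)cc1`, gives 10000 nM
compound 2, `COc1ccc(/C=C(/SCc2ccc(Cl)cc2)C(=O)c2ccc(Br)cc2)cc1O`, gives 1000 nM
compound 3, `COc1ccccc1/C=C(/SCc1ccc(Cl)cc1)C(=O)c1ccc(Br)cc1`, gives 1000 nM

Compound 3 stands level with compound 2, the two together giving the lowest numbers of the three; compound 1 sits furthest away. The measured steps are a 10-fold lower number from compound 1 to compound 2 (1.00 log units; beyond the scatter) and a 10-fold lower number from compound 1 to compound 3 (1.00 log units; beyond the scatter), while no change at the digits printed from compound 2 to compound 3 (within the scatter).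

Compound 4, `COc1ccccc1/C=C(/SCc1ccc(Cl)cc1)C(=O)c1ccc([N+](=O)[O-])cc1`, differs from compound 3 in one place: nitro in place of bromo on an aromatic carbon. Within the data shown here, every measured step concerns the other aryl group, the one on the double-bonded chain carbon, so no step bears on a change at the bromophenyl, and the three compounds give no guide to what a nitro in place of bromo does. Without such a step, the expectation is that compound 4 stays close to compound 3, with a step of no change at the digits printed from compound 3 to compound 4 (within the scatter) and no change beyond the scatter.

Compound 4 is therefore estimated at 1000 nM in this assay, within a range from 300 nM to 4000 nM.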

Compound 4, concentration for 50% growth inhibition: 10000 nM
The estimate for compound 4 lay 10-fold (1.00 log units) below the measured number, outside the stated range (above it).
By their numbers in this assay, from the lowest: compounds 2 and 3 (each within the scatter of the next); then compounds 1 and 4 (each within the scatter of the next).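

The ring carrying the bromo is not a silent position in this assay: nitro in place of bromo gives a 10-fold higher number from compound 3 to compound 4 (1.00 log units; beyond the scatter), so a change on this aromatic carbon, para to a large group, moves the number beyond the scatter. The earlier steps shown here showed such movement only at the other aryl group, and this single change weakens growth inhibition by as much as the change in a 10-fold lower number from compound 1 to compound 3 (1.00 log units; beyond the scatter) strengthens it. Nothing available explains why the nitro compound is the weaker inhibitor of growth.

As far as these compounds go, whether bromo is specifically favoured here, or nitro specifically disfavoured, remains open, and an amine or a carboxylic acid at this place could help to separate the two. From the compounds shown here alone, it is also open whether the same swap would have the same effect with the 3-hydroxy-4-methoxyphenyl group of compound 2.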